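Trading trifluoromethyl for chloro on compound 3

The source may hold more compounds than are shown below. What is called first, only, known or untested is meant among the compounds shown, and "the series" means these compounds.

Compound 1 `Cc1ccc(NC(=O)C2CCN(C/C=C/c3ccccc3)CC2)cc1`: 24100 nM
Compound 2 `CC(C)c1ccc(NC(=O)C2CCN(C/C=C/c3ccccc3)CC2)cc1`: 5200 nM
Compound 3 `O=C(Nc1cccc(C(F)(F)F)c1)C1CCN(C/C=C/c2ccccc2)CC1`: 9590 nM

Going by the values given here, in a functional assay on MGC-803 cells (Homo sapiens) for inhibition, read by MTT assay, with a stated time of 72 h (a higher number here means a weaker inhibitor, a lower number a stronger inhibitor), compound 3 gives 9590 nM and that value lies below the one of compound 1 by more than the scatter, while it cannot be told apart from the value of compound 2. Compound 4 `O=C(Nc1cccc(Cl)c1)C1CCN(C/C=C/c2ccccc2)CC1` carries chloro in place of trifluoromethyl on an aromatic carbon. Among the compounds with values here, the one measured step of a 4.6-fold lower number from compound 1 to compound 2 (0.67 log units; beyond the scatter) is modest and swaps different groups, so it bears only loosely on this change. Within the data shown here, no measured pair compares chloro with trifluoromethyl directly, so neither direction is favoured. The expected step is a 1.1-fold higher number from compound 3 to compound 4 (0.06 log units; within the scatter) and that means none beyond the scatter. Compound 4 is estimated at 11000 nM (expected range 5000 nM to 24000 nM).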

Compound 4, half-maximal inhibitory concentration: 11300 nM
Estimate against measurement, compound 4: 1.0-fold (0.01 log units) below; measured number inside the range.
By their numbers in this assay, from the lowest: compounds 2, 3 and 4 (each within the scatter of the next, the first and the last beyond it); then compound 1.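

In this assay, chloro can stand in for trifluoromethyl at this position with no change that can be told from scatter (a 1.2-fold higher number from compound 3 to compound 4 (0.07 log units; within the scatter)), even though one heavy atom replaces four. Like compound 3 before it, compound 4 sits clear of the 4-methylphenyl compound (a 2.1-fold lower number from compound 1 to compound 4 (0.33 log units; beyond the scatter)), but unlike compound 3 it is also clear of the 4-isopropylphenyl compound (a 2.2-fold higher number from compound 2 to compound 4 (0.34 log units; beyond the scatter)). No measurement at hand explains these numbers.

Going by these compounds, whether a methoxy group, an amine or a carboxylic acid in this place would shift the number beyond the scatter stays open. So does whether chloro and trifluoromethyl also match elsewhere on the ring.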